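This account rests on a few compounds, and the source may have more. Where it says the series, first, only, none or still open, it means among the compounds named here.

Compound 1, `COC(=O)[C@H](CCSC)NC(=O)c1ccc(NCc2cncn2Cc2ccc(Cl)cc2)cc1-c1ccccc1`, gives > 10 uM in a functional assay on NIH3T3 cells (Mus musculus); on this read-out higher numbers stand for an effect only at larger amounts of compound and lower numbers for an effect already at smaller amounts; this is a limit of the assay, not a number.
Compound 2, `COC(=O)[C@H](CCSC)NC(=O)c1ccc(NCc2cncn2Cc2cccc(C)c2)cc1-c1ccccc1`, gives > 10 uM in this assay; again a limit.
Compound 3, `COC(=O)[C@H](CCSC)NC(=O)c1ccc(NCc2cncn2Cc2ccccc2Cl)cc1-c1ccccc1`, gives > 10 uM in this assay; again a limit.

Among the measured compounds shown here, compound 3 therefore stands where every compound so far stands: at the limit of > 10 uM in this assay, at which 3 of the 3 values shown sit. None of the steps among them can be read: a step that the two limits leave unreadable from compound 1 to compound 2, a step that the two limits leave unreadable from compound 1 to compound 3 and a step that the two limits leave unreadable from compound 2 to compound 3 all remain of unknown size and direction.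

Compound 4, `COC(=O)[C@H](CCSC)NC(=O)c1ccc(NCc2cncn2Cc2ccc([N+](=O)[O-])cc2)cc1-c1ccccc1`, is the next compound to be measured in this assay. It differs from compound 3 in one place: 4-nitrophenyl in place of 2-chlorophenyl on a saturated chain carbon bound to an aromatic nitrogen. For the measured compounds named here, the steps that bear on this change, all involving a group on a saturated chain carbon bound to an aromatic nitrogen, gave no readable size, so there is no measured basis for expecting compound 4 to move beyond the scatter in either direction. The expected step is a step that the limit leaves unreadable from compound 3 to compound 4, and compound 4 is estimated at 20 uM, in a range from 5 uM to 100 uM.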

Compound 4, concentration for half-maximal effect: > 10 uM
Compound 4: only a limit was reported; the forecaster's own chance of this, stated with the estimate: 85%; the middle value does not contradict the limit.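

Among the compounds shown here, compound 4 gives > 10 uM in this assay, which is again a limit, so no step from compound 1, compound 2 or compound 3 to compound 4 can be read. All four compounds sit at the same place: the limit of > 10 uM in this assay, at which 4 of the 4 values shown sit.

From the compounds shown here alone, what stays open is whether these compounds differ at all in this assay and, if they do, by how much and in which direction.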